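Ethynyl removal from the ring-nitrogen aryl of compound 3

A few compounds are considered here, and "the series" means these few. Any claim that something is new, unique, unknown or untested is made for them only; others in the source may bear on it.

Among the measured compounds shown here, in a functional assay on HOS-TE85 cells (Homo sapiens) for inhibition, read by CCK-8 assay, with a stated time of 72 h (a higher number here means a weaker inhibitor, a lower number a stronger inhibitor), compound 3 `C#Cc1cccc(N2C(=O)CSC2c2cccc(C(=O)NCCCCc3ccccc3)c2)c1` gives 149 nM, the only number among the three measured compounds. Compound 1 `O=C(NCCCCc1ccccc1)c1cccc(C2SCC(=O)N2c2ccc(-c3ccccc3)cc2)c1` sits at the assay limit, > 1000 nM. Compound 2 `CCN(CC)c1ccc(N2C(=O)CSC2c2cccc(C(=O)NCCCCc3ccccc3)c2)cc1` likewise sits at the limit, > 1000 nM. The two measured steps onto compound 3 are an at least 6.7-fold lower number from compound 1 to compound 3 (0.82 log units; beyond the scatter) and an at least 6.7-fold lower number from compound 2 to compound 3 (0.82 log units; beyond the scatter); both replace the whole aryl on the ring nitrogen, and two of the three values are limits (the limit of > 1000 nM in this assay, at which 2 of the 3 values shown sit). Compound 4 `O=C(NCCCCc1ccccc1)c1cccc(C2SCC(=O)N2c2ccccc2)c1` differs from compound 3 by hydrogen in place of ethynyl on an aromatic carbon. For the measured compounds named here, no measured step removes a single substituent from that aryl; the contribution of the ethynyl alone is not readable from these data. A modest rise in the number is therefore expected in this assay, written as a 2.7-fold higher number from compound 3 to compound 4 (0.43 log units; beyond the scatter). Compound 4 is estimated at 400 nM, within 120 nM to 1500 nM.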

Compound 4, half-maximal inhibitory concentration: 15.9 nM
For compound 4 the middle estimate is 25-fold (1.40 log units) above the measured one; measured number below the stated range.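

In this assay, hydrogen in place of ethynyl gives a 9.4-fold lower number from compound 3 to compound 4 (0.97 log units; beyond the scatter), so the unsubstituted phenyl on the ring nitrogen outperforms the 3-ethynylphenyl, and the ethynyl brings no gain at this place. Hydrogen in place of diethylamino gives an at least 62-fold lower number from compound 2 to compound 4 (1.79 log units; beyond the scatter), and hydrogen in place of phenyl gives an at least 62-fold lower number from compound 1 to compound 4 (1.79 log units; beyond the scatter), so all three substituted aryls shown carry higher numbers than the phenyl of compound 4. Compound 1 and compound 2 are limits, which makes these last two steps bounds: the limit of > 1000 nM in this assay, at which 2 of the 4 values shown sit.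

On these data alone, whether any substituent on this ring is tolerated stays open. A fluorine, a methyl or a methoxy at the ethynyl's place would test this.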